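Working notes: from 3-fluorophenyl to 4-fluorophenyl

The compounds below may be only part of what the source reports. "The series", "measured", "known", "first", "only" and "open" are said of these compounds alone.

Measured in a functional assay on MCF7 cells (Homo sapiens) for antiproliferative activity, read by MTT assay, with a stated time of 72 h; on this read-out lower numbers stand for stronger inhibition and higher numbers for weaker inhibition:
compound 1 `COc1cc(-n2ncnc2-c2ccc(C)cc2)cc(OC)c1OC`: 540 nM
compound 2 `COc1cc(-n2ncnc2-c2cccc(F)c2)cc(OC)c1OC`: > 10000 nM

Compound 2 has only a limit and no number: the limit of > 10000 nM in this assay, at which 1 of the 2 values shown sits.

The next structure is compound 3 `COc1cc(-n2ncnc2-c2ccc(F)cc2)cc(OC)c1OC`, with 4-fluorophenyl in place of 3-fluorophenyl on an aromatic carbon. The group is attached to the same carbon of the five-membered aromatic ring with 3 nitrogen.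

Among the measured compounds shown here, only one measured step bears on this change: an at least 18-fold higher number from compound 1 to compound 2 (1.26 log units; beyond the scatter). That large step put 3-fluorophenyl in place of 4-methylphenyl, so it changed the substituent and its location together, and the two contributions cannot be separated. For the measured compounds named here, compound 3 shares the 4-substituted pattern of compound 1, which gives 540 nM, but no measured compound carries 4-fluorophenyl.

A lower number than the limit of compound 2 is therefore expected in this assay, though probably not a full return to the value of compound 1. The expected step is an at least 6.6-fold lower number from compound 2 to compound 3 (0.82 log units; beyond the scatter). For compound 3 the estimated value is 1500 nM, with an expected range of 200 nM to 8000 nM.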

Compound 3, half-maximal inhibitory concentration: > 10000 nM
Compound 3 was reported as a limit; the forecaster's own chance of this, stated with the estimate: 20%; middle value at least 6.6-fold (0.82 log units) away from the limit.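

Moving the fluoro from 3-fluorophenyl to 4-fluorophenyl brings no number back in this assay: compound 3 is reported only as a limit, > 10000 nM. The step between compound 2 and compound 3 cannot be read, with a limit on both sides: the limit of > 10000 nM in this assay, at which 2 of the 3 values shown sit.

Among the compounds shown here, the readable comparison is the one with compound 1, where fluoro in place of methyl gives an at least 18-fold higher number from compound 1 to compound 3 (1.26 log units; beyond the scatter), and this step changes the substituent alone, whereas the earlier step from compound 1 changed the substituent and its location together, so the change from methyl to fluoro is by itself enough to reach the limit of the assay.

From the compounds shown here alone, what remains open is whether the methyl is particular or whether another group in its place, such as methoxy, chloro, ethyl or an amine, would also give a value below the limit. The compounds shown also leave open how 3-methylphenyl would compare with 4-methylphenyl, and with it whether the location of a substituent on this phenyl ring matters at all in this assay.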